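Lipophilicity notes: aminopyridine biaryls, sulfonamide to amide

The source may hold more compounds than are shown below. What is called first, only, known or untested is meant among the compounds shown, and "the series" means these compounds.

Measured in a physicochemical assay for lipophilicity, at pH 7.4; on this read-out lower numbers stand for lower lipophilicity and higher numbers for higher lipophilicity:
compound 1 `CNS(=O)(=O)c1ccc(-c2cnc(N)c(-c3ccc(OC)nc3)c2)cc1`: 2.2
compound 2 `COc1ccc(-c2cnc(N)c(-c3ccc(OC)nc3)c2)cn1`: 2.8
compound 3 `COc1ccc(-c2cc(-c3ccc4cnn(C)c4c3)cnc2N)cn1`: 3

Compound 1 stands lowest of the three numbers in this assay. Its nearest neighbour is compound 2, whose value lies higher by a margin beyond the usual scatter; compound 3 lies further above still, also beyond the scatter. Among the compounds with values here, no step between two measured compounds that differ in a single place is available, so there is no directly measured template for the change considered here.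

Compound 4 `COc1ccc(-c2cc(-c3ccc(C(N)=O)cc3)cnc2N)cn1` is not yet measured. It differs from compound 1 in one place: carbamoyl in place of methylsulfamoyl on an aromatic carbon, para to a large group. The carbamoyl group is the smaller of the two, with one hydrogen-bond acceptor fewer. For this assay a modest downward step is expected, of a size that may or may not clear the scatter. The expected step is a number 0.30 log units lower from compound 1 to compound 4 (within the scatter). Compound 4 is estimated at 1.9, with a range from 1.4 to 2.4.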

Compound 4, distribution coefficient: 1.7
Compound 4: the middle estimate sits 0.20 log units above what was measured; measured number inside the range.
By their numbers in this assay, from the lowest: compound 4; then compound 1; then compounds 2 and 3 (each within the scatter of the next).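

In this assay, within the data shown here, the change from methylsulfamoyl to carbamoyl on an aromatic carbon, para to a large group, gives a number 0.50 log units lower from compound 1 to compound 4 (beyond the scatter) as the first step in this set that can be read at a single place. The read-out at this position therefore responds to this exchange by more than repeated measurements would scatter, even though the entering carbamoyl and the leaving methylsulfamoyl carry the same count of hydrogen-bond donors. Nothing at hand bears on why the number moves.

From the compounds shown here alone, the step rests on one pair, so whether it carries over to another core stays open. Also open, going by these compounds, is where a methylcarbamoyl group or a carboxylic acid at the same place would fall on this read-out.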